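The source may report more compounds than this note shows. Statements on the series, on what has been measured and on what is new or still open speak of the compounds shown alone.

Two compounds share a core and differ only at the amide end. Compound 1 `COc1cccc(CNC(=O)c2cccc(C(C)Oc3ccnc(Nc4cnn(C)c4)c3)c2)c1` carries a 3-methoxyphenyl there, and in a functional assay on HCC78 cells (Homo sapiens) for antiproliferative activity, read by MTT assay, with a stated time of 48 h (on this read-out higher numbers stand for weaker inhibition and lower numbers for stronger inhibition), compound 1 gives 64400 nM. Compound 2 `Cc1ccc(CNC(=O)c2cccc(C(C)Oc3ccnc(Nc4cnn(C)c4)c3)c2)cc1` carries a 4-methylphenyl instead, and in this assay compound 2 gives 8900 nM. That single swap produced a 7.2-fold lower number from compound 1 to compound 2 (0.86 log units; beyond the scatter), so compound 2 stands as the stronger of the two measured compounds.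

Compound 3 `Cc1ccc(CNC(=O)c2cccc(C(C)Oc3ccnc(Nc4cnn(CC(C)(C)O)c4)c3)c2)cc1` keeps everything in compound 2 and changes a different end of the molecule: 1-hydroxy-1-methylethyl in place of hydrogen on a saturated chain carbon bound to an aromatic nitrogen. Among the compounds with values here, no measured step touches this place; the one step known, from compound 1 to compound 2, concerns the amide end only, so it says nothing direct about what happens here. Without a comparison at this position, the plain expectation is that compound 3 stays close to compound 2, and the step of a 1.3-fold lower number from compound 2 to compound 3 (0.10 log units; within the scatter) is therefore estimated to sit within the ordinary scatter. In this assay compound 3 is expected to give about 7000 nM, with a likely range from 2000 nM to 25000 nM.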

Compound 3, half-maximal inhibitory concentration: 49700 nM
For compound 3 the middle estimate is 7.1-fold (0.85 log units) below the measured one, and the stated range ends below it.
By their numbers in this assay, from the lowest: compound 2; then compounds 3 and 1 (each within the scatter of the next).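

The end of the molecule carrying the 1-methyl-1H-pyrazol-4-yl group is not a silent place: in this assay, putting 1-hydroxy-1-methylethyl on the saturated chain carbon bound to the aromatic nitrogen gives a 5.6-fold higher number from compound 2 to compound 3 (0.75 log units; beyond the scatter) and so means weaker inhibition. The amide end is therefore no longer the only place where a single change is known to move the number beyond the scatter. This change, made with a 4-methylphenyl at the amide end, costs activity, but nothing shown explains the loss.

From the compounds shown here alone, what an ethyl, a 2-methylpropyl with no hydroxyl, or a longer chain ending in an amine or a carboxylic acid would do at this place stays open, so the step cannot yet be pinned on the hydroxyl or on the carbons that carry it. Going by these compounds, whether the same change would move the number in the same direction with a 3-methoxyphenyl at the amide end also remains open.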